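Methoxy on the indole: a small change repeated

The source may hold more compounds than are shown below. What is called first, only, known or untested is meant among the compounds shown, and "the series" means these compounds.

Of the compounds shown here, three built around a shared quinone core have been tested in a functional assay on MCF7 cells (Homo sapiens) for antiproliferative activity, read by CCK-8 assay, with a stated time of 48 h; a higher number here means a weaker inhibitor, a lower number a stronger inhibitor. Compound 1 `Cc1ccc(-c2[nH]c3ccccc3c2C2=C(Br)C(=O)C(c3c(C)[nH]c4ccccc34)=C(Br)C2=O)cc1` gives 3.25 ug/mL. Compound 2 `COc1ccc2[nH]c(C)c(C3=C(Cl)C(=O)C(c4c(-c5ccc(C)cc5)[nH]c5ccccc45)=C(Cl)C3=O)c2c1` gives 3.11 ug/mL. Compound 3 `Cc1ccc(-c2[nH]c3ccccc3c2C2=C(Cl)C(=O)C(c3c(C)[nH]c4ccccc34)=C(Cl)C2=O)cc1` gives 2.8 ug/mL. Compound 2 arises from compound 3 by one change, (methoxy in place of hydrogen on an aromatic carbon), and this change produced a 1.1-fold higher number from compound 3 to compound 2 (0.05 log units; within the scatter). How the core of compound 1 differs from the core of compound 3 is not broken down here.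

Compound 4 `COc1ccc2[nH]c(C)c(C3=C(Br)C(=O)C(c4c(-c5ccc(C)cc5)[nH]c5ccccc45)=C(Br)C3=O)c2c1` has not yet been measured. It arises from compound 1 by the same change, (methoxy in place of hydrogen on an aromatic carbon), made at the same place. Because the earlier step was a 1.1-fold higher number from compound 3 to compound 2 (0.05 log units; within the scatter), the step from compound 1 to compound 4 is expected to be a 1.1-fold higher number from compound 1 to compound 4 (0.03 log units; within the scatter), a shift too small to read as real. Compound 4 is therefore estimated at 3.5 ug/mL, between 2 ug/mL and 6 ug/mL.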

Compound 4, half-maximal inhibitory concentration: 2.56 ug/mL
Beside the measured number, compound 4's estimate is 1.4-fold (0.14 log units) above it; measured number inside the range.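

In this assay the methoxy step on the core of compound 1 is a small one (a 1.3-fold lower number from compound 1 to compound 4 (0.10 log units; within the scatter)) and cannot be read as a real change. Two cores are few, and a small true effect could hide inside the scatter, so this does not show that methoxy would be as silent on other cores. Set beside the earlier step, it shows only that on these two cores the change carries over as no measurable shift: the same change on two cores in this assay, a 1.1-fold higher number (0.05 log units; within the scatter) from compound 3 to compound 2 and a 1.3-fold lower number (0.10 log units; within the scatter) from compound 1 to compound 4, 1.4-fold (0.15 log units) apart, within the scatter of two such steps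

The compounds shown leave open whether any other group at this place on the indole would move the number, such as an amine, a carboxylic acid or a longer chain. A real shift from a change at this place remains to be seen in this series.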